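Oxazolidinone hexanamides: aryl substituent switch from carbamoyl to trifluoromethyl

This account rests on a few compounds, and the source may have more. Where it says the series, first, only, none or still open, it means among the compounds named here.

Measured so far:
- compound 1, `O=C(CCCCCc1cccc(I)c1)N1CCOC1=O`: 3120 nM
- compound 2, `NC(=O)c1cccc(CCCCCC(=O)N2CCOC2=O)c1`: > 20000 nM

In an assay on HEK293 cells for inhibition of N-acylethanolamine-hydrolyzing acid amidase (Rattus norvegicus), read by LC-MS, with a stated time of 30 min (on this read-out higher numbers stand for weaker inhibition and lower numbers for stronger inhibition), compound 1 gives 3120 nM. For compound 2 only a limit of the assay is known, > 20000 nM, so compound 2 sits at the limit of > 20000 nM in this assay, at which 1 of the 2 values shown sits, and no number is available for it. Among the measured compounds shown here, the one measured step, an at least 6.4-fold higher number from compound 1 to compound 2 (0.80 log units; beyond the scatter), is the only comparison and it points in the direction of weaker inhibition when the iodo group is exchanged.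

Compound 3, `O=C(CCCCCc1cccc(C(F)(F)F)c1)N1CCOC1=O`, differs from compound 2 by trifluoromethyl in place of carbamoyl on an aromatic carbon. This change undoes the carbamoyl of compound 2 and returns to a compact substituent at the same ring carbon, as in compound 1. Since the only shown step, from compound 1 to compound 2, was at least modest and toward weaker inhibition, the reverse exchange is expected to move back toward the level of compound 1 in this assay. Compound 3 is therefore expected to give about 5000 nM, within 1500 nM to 20000 nM, meaning an estimated at least 4.0-fold lower number from compound 2 to compound 3 (0.60 log units; beyond the scatter).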

Compound 3, half-maximal inhibitory concentration: 58 nM
Estimate against measurement, compound 3: 86-fold (1.94 log units) above; measured number below the stated range.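

At this aromatic carbon, the substituent moves inhibition in this assay over a far wider span than compound 1 and compound 2 had shown, and the iodo group proves not to be the upper end of the series: trifluoromethyl in place of iodo gives a 54-fold lower number from compound 1 to compound 3 (1.73 log units; beyond the scatter). Trifluoromethyl in place of carbamoyl gives an at least 340-fold lower number from compound 2 to compound 3 (2.53 log units; beyond the scatter), the largest step read so far in this series, which shows that the exchange at this single carbon can decide between strong inhibition and none detectable within the range of this assay. The true size of that step stays open-ended, because compound 2 has only a limit of the assay and not a number: the limit of > 20000 nM in this assay, at which 1 of the 3 values shown sits.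

The compounds shown do not tell which feature of trifluoromethyl goes with the stronger inhibition, and a nitrile, a methoxy group or a chlorine at the same carbon would narrow this down. From the compounds shown here alone, whether the gain holds with trifluoromethyl at another carbon of the ring, or with a longer chain in place of the present one, also remains open.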